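The source may report more compounds than this note shows. Statements on the series, on what has been measured and on what is new or still open speak of the compounds shown alone.

Measured compounds:
compound 1, `CCNc1[nH]c(=O)n(O)c(=O)c1C(=O)NCc1ccccc1`: 732 uL/min
compound 2, `CCNc1[nH]c(=O)n(O)c(=O)c1C(=O)NCc1cccc(Cl)c1F`: 1070 uL/min
compound 3, `CCNc1[nH]c(=O)n(O)c(=O)c1C(=O)NCc1ccc(F)cc1`: 1240 uL/min

These three share one core and differ only in the aromatic ring attached to a saturated chain carbon bound to an amide-type nitrogen. In an ADME assay on microsomes from liver (Mus musculus) for metabolic stability (on this read-out higher numbers stand for fast clearance and lower numbers for slow clearance), compound 3 gives 1240 uL/min. Its distance to the other two is small: a 1.7-fold higher number from compound 1 to compound 3 (0.23 log units; within the scatter) and a 1.2-fold higher number from compound 2 to compound 3 (0.06 log units; within the scatter), so all three numbers sit together.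

Compound 4, `CCNc1[nH]c(=O)n(O)c(=O)c1C(=O)NCc1ccc(C)c(F)c1`, is not yet measured. It differs from compound 3 as follows: 3-fluoro-4-methylphenyl in place of 4-fluorophenyl on a saturated chain carbon bound to an amide-type nitrogen. Going by the values given here, the steps that bear on this are the earlier swaps of one aromatic ring for another at the same place, a 1.5-fold higher number from compound 1 to compound 2 (0.16 log units; within the scatter) and a 1.2-fold higher number from compound 2 to compound 3 (0.06 log units; within the scatter), both within the scatter. Nothing in these three compounds links a change of the aromatic ring to a shift in this assay beyond the scatter, so for compound 4 the expected step is a 1.0-fold lower number from compound 3 to compound 4 (0.01 log units; within the scatter). Compound 4 is therefore estimated at 1200 uL/min, with a range from 600 uL/min to 2400 uL/min.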

Compound 4, intrinsic clearance in a liver preparation (reported as CLH), per the amount of preparation that the assay uses: 1340 uL/min
Compound 4: the middle estimate sits 1.1-fold (0.05 log units) below what was measured; measured number inside the range.
By their numbers in this assay, from the lowest: compounds 1, 2, 3 and 4 (each within the scatter of the next).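

Going by these compounds alone, the ring in compound 4 is the first here to carry a methyl group, and in this assay this brings no step beyond the scatter: a 1.1-fold higher number from compound 3 to compound 4 (0.03 log units; within the scatter), a 1.3-fold higher number from compound 2 to compound 4 (0.10 log units; within the scatter) and a 1.8-fold higher number from compound 1 to compound 4 (0.26 log units; within the scatter). At this place, on a saturated chain carbon bound to an amide-type nitrogen, all four compounds now lie within the scatter of one another, so the insensitivity seen among the three earlier rings also holds for 3-fluoro-4-methylphenyl. No measurement shown here explains this sameness.

The rings shown carry only fluorine, chlorine or methyl, or nothing at all, so it remains open whether an amine or a carboxylic acid on the ring would shift the number. Also open, from the compounds shown here alone, is what a longer chain between the ring and the amide-type nitrogen would do.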